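One Methyl Group in Two Places, Compared for Efficacy

The source may report more compounds than this note shows. Statements on the series, on what has been measured and on what is new or still open speak of the compounds shown alone.

Measured compounds in an in vitro functional assay on 1321-N1 cells for agonist activity at Free fatty acid receptor 1 (Homo sapiens), read by fluorescence, spectrophotometry and calcium flux; on this read-out higher numbers stand for larger maximal responses and lower numbers for smaller maximal responses:
compound 1, `Cc1c(C#Cc2ccc(CCC(=O)O)cc2)cc(Cl)nc1Cl`, 91%;
compound 2, `O=C(O)CCc1ccc(C#Cc2ccccn2)cc1`, 98%;
compound 3, `O=C(O)CCc1ccc(C#Cc2cc(Cl)nc(Cl)c2)cc1`, 103%.

Within the shared core of compounds 3 and 1 a single change, (methyl in place of hydrogen on an aromatic carbon), gave a number 12 percentage points lower from compound 3 to compound 1 (beyond the scatter). The difference between the cores of compounds 2 and 3 is not broken down here; their values in this assay lie within the scatter of each other.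

Compound 4, `Cc1cccc(C#Cc2ccc(CCC(=O)O)cc2)n1`, is made from compound 2 by methyl in place of hydrogen on an aromatic carbon. This is the same kind of change as from compound 3 to compound 1, but the place differs: in compound 1 the methyl sits ortho to a chloro group, ortho to a large group, two atoms from the ring nitrogen and para to a chloro group, whereas in compound 4 it sits next to the ring nitrogen and meta to a large group.

Resting on a number 12 percentage points lower from compound 3 to compound 1 (beyond the scatter) and on the value of compound 2, 98%, the step expected from compound 2 to compound 4 is a number 10 percentage points lower from compound 2 to compound 4 (within the scatter). Compound 4 is therefore estimated at 88%, between 74% and 102%.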

Compound 4, largest response reached (reported as efficacy), in percent of the reference or control that the assay uses: 108%
Compound 4: the middle estimate sits 20 percentage points below what was measured; the whole stated range lies below it.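

In this assay, methyl in place of hydrogen on an aromatic carbon gave a number 10 percentage points higher from compound 2 to compound 4 (within the scatter), a step that stays within the usual spread of repeated measurements on the core of compound 2. Set beside the earlier step, the change did not carry over unaltered from one core to the other: the same change on two cores in this assay, a number 12 percentage points lower (beyond the scatter) from compound 3 to compound 1 and a number 10 percentage points higher (within the scatter) from compound 2 to compound 4, 22 percentage points apart, beyond the scatter of two such steps The two steps differ both in the core and in the place of the methyl, and these compounds do not separate the two, so they do not show which of them accounts for the gap.

Going by these compounds, it remains open how an ethyl group, a methoxy group or an amine would read in the same place, next to the ring nitrogen, on the core of compound 2. On these data alone, whether a methyl next to the ring nitrogen on another core would repeat the step to compound 4 is also open.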